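The source may report more compounds than this note shows. Statements on the series, on what has been measured and on what is new or still open speak of the compounds shown alone.

Measured so far:
- compound 1, `CCCCOC(=O)Nc1ccc([Se]C#N)cc1`: in a physicochemical assay, with a stated time of 180 min, tested at 0.5 mg/mL (a higher number here means more inhibition at the concentration tested (going by the name of the read-out), a lower number less inhibition), compound 1 gives 6.6%.
- compound 2, `CCCCCCOC(=O)Nc1ccc([Se]C#N)cc1`: compound 2 gives > 25%, a limit of the assay and not a number.
- compound 3, `N#C[Se]c1ccc(NC(=O)Oc2ccccc2)cc1`: compound 3 gives 19.3%.

Compound 2 therefore stands only at a limit, with a range rather than a number, (the limit of > 25% in this assay, at which 1 of the 3 values shown sits). Compound 4, `N#C[Se]c1ccc(NC(=O)OCc2ccccc2)cc1`, differs from compound 2 thus: phenyl in place of pentyl on a saturated chain carbon bound to an oxygen next to a carbonyl group. Among the measured compounds shown here, two measured steps bear on it: a number 12.7 percentage points higher from compound 1 to compound 3 (beyond the scatter), whereas a number at least 5.7 percentage points lower from compound 2 to compound 3 (that floor lies within the scatter). Compound 4 keeps a chain carbon on that oxygen and adds phenyl, so from compound 2 the expected step for compound 4 is a number at least 4 percentage points lower from compound 2 to compound 4 (that floor lies within the scatter), small or none beyond the scatter. Compound 4 is estimated at 21%, expected between 9% and 33%.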

Compound 4, a percentage reported as inhibition, at one concentration (the size of the read-out at that concentration, not a potency): 3.7%
Estimate against measurement, compound 4: 17.3 percentage points above; the measured number lies below the stated range.
By their numbers in this assay, from the lowest: compounds 4 and 1 (each within the scatter of the next); then compound 3. At a limit, above all of these: compound 2.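

In this assay, phenyl in place of pentyl on a saturated chain carbon bound to an oxygen next to a carbonyl group does not keep the reading of the longer chain: a number at least 21.3 percentage points lower from compound 2 to compound 4 (beyond the scatter). Compound 2 gives > 25%, which is a limit of the assay and not a number. Phenyl in place of propyl at the same place separates nothing: a number 2.9 percentage points lower from compound 1 to compound 4 (within the scatter).

The compounds shown leave open how a longer chain than hexyl would read in this assay. On these data alone, an amine on the chain carbon is also open.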